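A few compounds are considered here, and "the series" means these few. Any claim that something is new, unique, unknown or untested is made for them only; others in the source may bear on it.

Measured so far, in an ADME assay on L1210/0 cells (Mus musculus) for cytotoxicity, with a stated time of 48 h; on this read-out higher numbers stand for weaker inhibition and lower numbers for stronger inhibition:
compound 1 `COc1ccc(C(=O)/C=C/c2cc(=O)[nH]c(=O)n2COCCO)cc1` gives 33500 nM
compound 2 `Cc1ccc(C(=O)/C=C/c2cc(=O)[nH]c(=O)n2COCCO)cc1` gives 27900 nM
compound 3 `Cc1ccc(C(=O)/C=C/c2cc(O)nc(O)n2)cc1` gives 182000 nM

Compound 2 and compound 1 share one core and differ only in one place: methoxy in place of methyl on an aromatic carbon. The step from this change, a 1.2-fold higher number from compound 2 to compound 1 (0.08 log units; within the scatter), is small. Compound 3 carries a second core; how this core differs from that of compound 2 is not broken down here, and in this assay compound 3 gives 182000 nM, the highest of the three numbers.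

Compound 4 `COc1ccc(C(=O)/C=C/c2cc(O)nc(O)n2)cc1` is not yet measured. Compound 4 differs from compound 3 by the same change seen between compound 2 and compound 1, (methoxy in place of methyl on an aromatic carbon), at the same place on the ring. Because a 1.2-fold higher number from compound 2 to compound 1 (0.08 log units; within the scatter) is within the scatter, the step for compound 4 is estimated as a 1.1-fold higher number from compound 3 to compound 4 (0.04 log units; within the scatter). In this assay compound 4 is therefore expected to give about 200000 nM, between 90000 nM and 450000 nM.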

Compound 4, half-maximal inhibitory concentration: > 200000 nM
Compound 4 ended at the assay's limit; the forecaster's own chance of this, stated with the estimate: 25%; the middle value sits exactly at the limit.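

On the core of compound 3, methoxy in place of methyl gives an at least 1.0-fold higher number from compound 3 to compound 4 (0.04 log units; that floor lies within the scatter) in this assay. Compound 4 gives > 200000 nM and that is a limit of the assay, not a number. Set beside the earlier step, the new one shows no conflict between the two cores, but it does not show that the change carries over with the same size: the same change on two cores in this assay, a 1.2-fold higher number (0.08 log units; within the scatter) from compound 2 to compound 1 and an at least 1.0-fold higher number (0.04 log units; that floor lies within the scatter) from compound 3 to compound 4; the limit leaves it open whether they differ

Only methyl and methoxy appear on this aromatic carbon among the compounds shown. From the compounds shown here alone, what an amine, a carboxylic acid or a longer chain would give there on either core remains open.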